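A few compounds are considered here, and "the series" means these few. Any claim that something is new, unique, unknown or untested is made for them only; others in the source may bear on it.

In an ADME assay on PC-3 cells (Homo sapiens) for cytotoxicity, read by WST assay, tested at 100 uM (on this read-out lower numbers stand for less inhibition and higher numbers for more inhibition at the one concentration tested (going by the name of the read-out)), the two compounds measured so far gave these numbers:

Compound 1, `CS(=O)(=O)Nc1cccc(C(=O)N2CCCC(C(=O)Nc3ccc(Cl)cc3)C2)c1`: 3%
Compound 2, `N#Cc1cccc(C(=O)N2CCCC(C(=O)Nc3ccc(Cl)cc3)C2)c1`: 0%

Compound 2 stands lowest of the two numbers in this assay; its nearest neighbour is compound 1, and the two lie within the scatter of each other. Within the data shown here, the only measured step is a number 3 percentage points lower from compound 1 to compound 2 (within the scatter), which changed the group on the same aromatic carbon that is now altered again and moved the read-out by no more than the usual scatter.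

Compound 3, `O=C(c1ccccc1)c1cccc(C(=O)N2CCCC(C(=O)Nc3ccc(Cl)cc3)C2)c1`, is the compound not yet measured. It differs from compound 2 as follows: benzoyl in place of cyano on an aromatic carbon. Among the measured compounds shown here, the one step that bears on this change is the step from compound 1 to compound 2, which was within the scatter; there is no measured step involving a benzoyl group, so the account rests on that single small step alone. On this basis a step of a number 5 percentage points higher from compound 2 to compound 3 (within the scatter) is expected, that is, nothing beyond the scatter. For compound 3 the estimate in this assay is 5%, with a range from 0% to 20%.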

Compound 3, a percentage reported as inhibition, at one concentration (the size of the read-out at that concentration, not a potency): 0%
The estimate for compound 3 lay 5 percentage points above the measured number; low and high end bracket the measured number.
By their numbers in this assay, from the lowest: compounds 2, 3 and 1 (each within the scatter of the next).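

In this assay, three different groups have now been read on the aromatic carbon meta to a large group, and the new compound sits within the scatter of both others, with no change at the digits printed from compound 2 to compound 3 (within the scatter) and with a number 3 percentage points lower from compound 1 to compound 3 (within the scatter) as its steps. What the earlier pair did not show is that this also holds for benzoyl, which has 8 heavy atoms and a six-membered aromatic ring of carbon only, in place of cyano, which has 2 heavy atoms and no ring. Across compounds 1, 2 and 3, then, neither the larger group nor the added ring goes with a step beyond the scatter at the one concentration tested, and nothing given here offers an explanation for this.

The compounds shown leave open whether a group of another kind on this carbon, such as an amine, a carboxylic acid or a longer alkyl chain, would also stay within the scatter of these numbers. They also leave open whether a change elsewhere on the shared core would move the read-out in this assay beyond the scatter.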